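The source may hold more compounds than are shown below. What is called first, only, known or untested is meant among the compounds shown, and "the series" means these compounds.

Compounds 1, 2 and 3 have been tested in an ADME assay on L929 cells (Mus musculus) for cytotoxicity, read by resazurin assay, with a stated time of 72 h; on this read-out lower numbers stand for stronger inhibition and higher numbers for weaker inhibition. Compound 1 `COc1cccc(C(=O)CCc2ccc3c(c2)B(O)OC3)c1` gives only a limit of the assay, > 10 ug/mL. Compound 2 `COc1ccccc1C(=O)/C=C/c1ccc2c(c1)B(O)OC2` gives 6.35 ug/mL in this assay, and compound 3 `COc1ccc(C(=O)/C=C/c2ccc3c(c2)B(O)OC3)c(OC)c1` gives 7.87 ug/mL. Compound 4 `O=C(CCc1ccc2c(c1)B(O)OC2)c1ccccc1` has not yet been measured.

Compound 3 and compound 2 differ in one place, (hydrogen in place of methoxy on an aromatic carbon), and the step is a 1.2-fold lower number from compound 3 to compound 2 (0.09 log units; within the scatter). Compound 1 and compound 3 are built on different cores, but the difference between the two cores is not broken down here. Compound 4 is related to compound 1 by the same kind of change, (hydrogen in place of methoxy on an aromatic carbon); around the place the two differ, since in compound 1 it is meta to a large group, whereas in compound 3 it is meta to a methoxy group and para to a large group.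

A small step from compound 1 to compound 4 is expected, a step that the limit leaves unreadable from compound 1 to compound 4, because a 1.2-fold lower number from compound 3 to compound 2 (0.09 log units; within the scatter) stays within the scatter. Compound 1 itself sits at the limit (the limit of > 10 ug/mL in this assay, at which 1 of the 3 values shown sits). Compound 4 is therefore estimated at 12 ug/mL, between 6 ug/mL and 30 ug/mL, and may itself return only a limit.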

Compound 4, half-maximal inhibitory concentration: > 10 ug/mL
Compound 4: a limit, no number; the forecaster's own chance of this, stated with the estimate: 60%; the middle value is on the limit's open side.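

Compound 1 and compound 4 both return only a limit in this assay, so no step can be read for the change from methoxy to hydrogen between them: the limit of > 10 ug/mL in this assay, at which 2 of the 4 values shown sit.

The compounds shown leave open what the actual values of compound 1 and compound 4 are, and so whether this change on their shared core alters the read-out at all.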